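The source may report more compounds than this note shows. Statements on the series, on what has been measured and on what is new or still open speak of the compounds shown alone.

Measured compounds:
compound 1 `CCC[C@@H](NC(=O)c1cnccn1)C(=O)N[C@@H](CC(C)C)B(O)O` with 187 nM
compound 2 `CCCC[C@@H](NC(=O)c1cnccn1)C(=O)N[C@@H](CC(C)C)B(O)O` with 93 nM
compound 3 `CC(C)C[C@H](NC(=O)[C@H](NC(=O)c1cnccn1)C(C)C)B(O)O` with 546 nM

In an assay on isolated protein for inhibition of Lon protease homolog, mitochondrial (Homo sapiens), read by HTRF, with a stated time of 50 min, in the presence of a further agent that is not named here (a higher number here means a weaker inhibitor, a lower number a stronger inhibitor), compound 3 stands highest: a 2.9-fold higher number from compound 1 to compound 3 (0.47 log units; beyond the scatter) and a 5.9-fold higher number from compound 2 to compound 3 (0.77 log units; beyond the scatter). Compound 4, `CC(C)C[C@H](NC(=O)[C@H](NC(=O)c1cnccn1)C(C)(C)C)B(O)O`, is not yet measured. The two cores differ in the way given by isopropyl in place of propyl on a saturated chain carbon bound to an amide-type nitrogen and a carbonyl carbon. The change from compound 3 to compound 4 is methyl in place of hydrogen on a saturated chain carbon bound to three saturated chain carbons; the same kind of change was made from compound 1 to compound 2, namely (methyl in place of hydrogen on a saturated chain carbon, four bonds along the chain from an amide-type nitrogen and a carbonyl carbon), where it gave a 2.0-fold lower number from compound 1 to compound 2 (0.30 log units; within the scatter). The surroundings differ: there the methyl entered four bonds along the chain from an amide-type nitrogen and a carbonyl carbon, here on a saturated chain carbon bound to three saturated chain carbons. Because the earlier step was a 2.0-fold lower number from compound 1 to compound 2 (0.30 log units; within the scatter), a step of similar size is expected here, a 1.4-fold lower number from compound 3 to compound 4 (0.14 log units; within the scatter). For compound 4 the estimated value in this assay is 400 nM, between 150 nM and 1200 nM.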

Compound 4, half-maximal inhibitory concentration: 2850 nM
For compound 4 the middle estimate is 7.1-fold (0.85 log units) below the measured one, and the stated range ends below it.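

In this assay, the added methyl does not behave the same way on the two cores, so the step seen on the core of compound 1 cannot be carried over to the core of compound 3: the same change on two cores in this assay, a 2.0-fold lower number (0.30 log units; within the scatter) from compound 1 to compound 2 and a 5.2-fold higher number (0.72 log units; beyond the scatter) from compound 3 to compound 4, 10-fold (1.02 log units) apart, beyond the scatter of two such steps

Going from isopropyl to tert-butyl gives a 5.2-fold higher number from compound 3 to compound 4 (0.72 log units; beyond the scatter), and the comparisons with the unbranched chains give a 31-fold higher number from compound 2 to compound 4 (1.49 log units; beyond the scatter) and a 15-fold higher number from compound 1 to compound 4 (1.18 log units; beyond the scatter). Among these compounds, with only one pair on each core, these results cannot separate the place of the methyl from the rest of the core, and they give no reason for the gap.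

Going by these compounds, it remains open how a longer chain such as pentyl, or a chain carrying an amine, would compare with tert-butyl.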